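The source may hold more compounds than are shown below. What is called first, only, known or untested is meant among the compounds shown, and "the series" means these compounds.

Working notes on the series. Compound 1 `COc1ccc(OC)c(-c2cc(-c3ccc(C(=O)N4CCCC4)s3)on2)c1` carries a 2,5-dimethoxyphenyl on the shared core and in a functional assay on A549 cells (Homo sapiens) for cytotoxicity, read by XTT assay, with a stated time of 72 h (on this read-out higher numbers stand for weaker inhibition and lower numbers for stronger inhibition), gives only a limit of the assay, > 30000 nM. Compound 2 `CN(Cc1ccccc1)C(=O)c1ccc(-c2cc(C3=CC(=O)C=CC3=O)no2)s1` in this assay likewise gives only a limit, > 30000 nM. Going by the values given here, both values sit at the limit of > 30000 nM in this assay, at which 2 of the 2 values shown sit, so no measured step separates them. Compound 3 `COc1ccc(OC)c(-c2cc(-c3ccc(C(=O)N(C)Cc4ccccc4)s3)on2)c1` differs from compound 2 by a group of 10 heavy atoms (8 carbon, 2 oxygen; one six-membered aromatic ring of carbon only) in place of a group of 8 heavy atoms (6 carbon, 2 oxygen; one six-membered non-aromatic ring of carbon only), on an aromatic carbon. Among the compounds with values here, no measured step of this kind is known; the change is expected to bring no shift beyond the scatter, a step that the limit leaves unreadable from compound 2 to compound 3. Compound 3 is estimated in this assay at 50000 nM, between 15000 nM and 150000 nM, most likely reported again only as a limit.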

Compound 3, half-maximal inhibitory concentration: > 30000 nM
Compound 3: only a limit was reported; the forecaster's own chance of this, stated with the estimate: 80%; the middle value does not contradict the limit.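

Compound 3 also gives only a limit, so the steps to it from compound 1 and compound 2 cannot be read: the limit of > 30000 nM in this assay, at which 3 of the 3 values shown sit. On these data alone, what the swaps of 2,5-dimethoxyphenyl and benzyl(methyl)amino do to the read-out in this assay stays open.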